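A few compounds are considered here, and "the series" means these few. Any claim that something is new, unique, unknown or untested is made for them only; others in the source may bear on it.

Three compounds share a closely related core. In an ADME assay on Caco-2 cells (Homo sapiens) for permeability (on this read-out lower numbers stand for lower permeability and higher numbers for higher permeability), compound 1 `N=S1(=O)c2ccccc2C(=O)N1c1ccccc1` shows "not determined" (no result reported), so it carries no result. In this assay compound 2 `O=S1(=O)N=C(Nc2ccccc2)c2ccccc21` shows "not determined" (no result reported), so it carries no result either. Within the data shown here, compound 3 `N=S1(=O)c2ccccc2C(=O)N1Cc1ccccc1` is the one compound with a number: in this assay compound 3 gives 84.7 10^-6 cm/s, so it is the only measured point and stands alone, with nothing to rank it against. Compound 4 `CCN1C(=O)c2ccccc2S1(=N)=O` has not yet been tested. Compared with compound 3, compound 4 has methyl in place of phenyl on a saturated chain carbon bound to an amide-type nitrogen in a ring. Since no step between two measured compounds is shown, nothing here tells how large such a change usually is; the expectation for compound 4 is a small step, if any, in this assay, at most a modest decrease and plausibly within the scatter, expressed as a 1.5-fold lower number from compound 3 to compound 4 (0.19 log units; within the scatter). For compound 4 the estimated value in this assay is 55 10^-6 cm/s, expected to lie between 25 10^-6 cm/s and 100 10^-6 cm/s.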

Compound 4, apparent permeability in the Caco-2 assay: 92 10^-6 cm/s
Compound 4: middle estimate off by 1.7-fold (0.22 log units), on the low side, within the range that was stated.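

In the Caco-2 assay, methyl in place of phenyl gives a 1.1-fold higher number from compound 3 to compound 4 (0.04 log units; within the scatter), so this read-out does not separate the two groups at this place, on a saturated chain carbon bound to an amide-type nitrogen in a ring. In a physicochemical assay for acid dissociation, read by spectrophotometry, compound 3 gives 8.7 and compound 4 gives 8.9 as a pair that also stays within the scatter. No measured evidence on why either read-out stays level is available here. Still open, on these data alone, is whether a longer chain, an amine or a carboxylic acid at this place would move either read-out.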